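Swapping butyl for bromo on an arylurea in a whole-organism readout

The compounds below may be only part of what the source reports. "The series", "measured", "known", "first", "only" and "open" are said of these compounds alone.

The series consists of three measured ureas and one untested analogue. In an ADME assay on the whole organism with Oryza sativa as the target, tested at 10 uM (a lower number here means a stronger effect, a higher number a weaker effect of the compound at the concentration tested), compound 1 `CCCCc1ccc(NC(=O)N[C@H](C)c2ccccc2)cc1` gives 28%, while its epimer compound 2 `CCCCc1ccc(NC(=O)N[C@@H](C)c2ccccc2)cc1` gives 60%, and compound 3 `C[C@@H](NC(=O)Nc1ccccc1Cl)c1ccccc1` gives 93%. Within the data shown here, the one step measured within this set, a number 32 percentage points higher from compound 1 to compound 2 (beyond the scatter), rests on the fact that compounds 1 and 2 differ only in the configuration as drawn alone. Compound 2 therefore stands second highest of the three numbers, lying between compound 1 and compound 3 and separated from each by more than the scatter.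

Compound 4 `C[C@H](NC(=O)Nc1ccc(Br)cc1)c1ccccc1` differs from compound 2 in one place: bromo in place of butyl on an aromatic carbon. Among the measured compounds shown here, none of the measured steps involves this exchange, since the only measured step concerns a change of configuration and not a change of substituent, so it gives no direction for the step in this assay. Compound 4 is therefore expected to give a value in this assay close to that of compound 2, with the step of a number 5 percentage points higher from compound 2 to compound 4 (within the scatter) estimated as lying within the scatter. The estimate for compound 4 is 65%, expected to fall between 35% and 95%.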

Compound 4, a percentage reported as activity, at one concentration (the size of the read-out at that concentration, not a potency): 96%
For compound 4 the middle estimate is 31 percentage points below the measured one; the whole stated range lies below it.
By their numbers in this assay, from the lowest: compound 1; then compound 2; then compounds 3 and 4 (each within the scatter of the next).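

In this assay, the aromatic carbon para to a large group proves sensitive to its substituent: bromo in place of butyl gives a number 36 percentage points higher from compound 2 to compound 4 (beyond the scatter). Among these compounds, until now, only a change of configuration had been seen to move the number, so this is the first large step that comes from exchanging a substituent, and here the weaker effect goes with bromo and the stronger effect with butyl. Nothing shown explains this step, since the only available fact concerns configuration and does not bear on this exchange.

The compounds shown leave open whether a shorter chain such as ethyl, a longer chain such as hexyl, or an amine at this carbon would sit nearer compound 2 or compound 4. They also leave open whether the configuration drawn in compound 1 would change the number when bromo replaces butyl.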